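A few compounds are considered here, and "the series" means these few. Any claim that something is new, unique, unknown or untested is made for them only; others in the source may bear on it.

Compound 3, `COc1ccc(/C(C)=N/NC(=S)NC(C)(C)[C@H]2CC=C(C)CC2)cc1`, has only a limit in a functional assay on MCF7 cells (Homo sapiens) for inhibition, read by sulforhodamine B assay, with a stated time of 48 h; a lower number here means a stronger inhibitor of growth, a higher number a weaker inhibitor of growth: it gives > 100000 nM. Compound 2, `CC1=CC[C@H](C(C)(C)NC(=S)N/N=C(\C)c2ccccc2)CC1`, likewise stops at a limit in this assay, giving > 100000 nM. Compound 1, `CC1=CC[C@H](C(C)(C)NC(=S)N/N=C/c2ccccc2)CC1`, gives 84400 nM in this assay. For the measured compounds named here, the one measured step next to compound 3, a step that the two limits leave unreadable from compound 2 to compound 3, cannot be sized, because the limit of > 100000 nM in this assay, at which 2 of the 3 values shown sit, hides its size. Compound 4, `CC1=CC[C@H](C(C)(C)NC(=S)N/N=C(\C)c2ccc([N+](=O)[O-])cc2)CC1`, differs from compound 3 by nitro in place of methoxy on an aromatic carbon. No readable measured step bears on this change, so the account starts from the limit of compound 3 alone and expects no step beyond the scatter, a step that the limit leaves unreadable from compound 3 to compound 4. Compound 4 is therefore estimated at 120000 nM, within a range from 40000 nM to 350000 nM, with a fair chance that this assay again reports only a limit.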

Compound 4, concentration for total growth inhibition: 77500 nM
Compound 4: the middle estimate sits 1.5-fold (0.19 log units) above what was measured; low and high end bracket the measured number.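

Nitro on the aromatic carbon para to a large group makes this position readable for the first time: in this assay compound 4 gives 77500 nM, a number and not a limit. Nitro in place of methoxy gives an at least 1.2-fold lower number from compound 3 to compound 4 (0.11 log units; that floor lies within the scatter), and nitro in place of hydrogen gives an at least 1.2-fold lower number from compound 2 to compound 4 (0.11 log units; that floor lies within the scatter). Neither step has a true size, only a floor, because each starts from a limit: the limit of > 100000 nM in this assay, at which 2 of the 4 values shown sit.

On these data alone, how large the nitro step really is stays open. So does whether an amine or a carboxylic acid on this aromatic carbon would also give a number rather than a limit.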